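Undoing a Urea Extension: From Compound 2 to Compound 4

The source may report more compounds than this note shows. Statements on the series, on what has been measured and on what is new or still open speak of the compounds shown alone.

Compound 2 `COc1cc(NC(C)CCCNC(=O)NNC(=O)Nc2ccc(O)cc2)c2ncccc2c1` stands at the weak end of this small set. In a functional assay on L1210 cells (Mus musculus) for inhibition, read by MTT assay, with a stated time of 72 h (a lower number here means a stronger inhibitor, a higher number a weaker inhibitor), compound 2 gives 95000 nM, the highest number of the three measured compounds. Compound 1 `COc1cc(NC(C)CCCNC(=O)Nc2ccc(C(F)(F)F)cc2)c2ncccc2c1` gives 7400 nM in this assay, and compound 3 `COc1cc(NC(C)CCCNC(=O)Nc2cc(C(F)(F)F)cc(C(F)(F)F)c2)c2ncccc2c1` gives 3500 nM, so compound 2 sits beyond the scatter of both.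

Compound 4 `COc1cc(NC(C)CCCNC(=O)Nc2ccc(Cl)cc2)c2ncccc2c1` is now to be measured in this assay. It differs from compound 2 in one place: 4-chlorophenyl in place of ((4-hydroxyphenyl)carbamoyl)amino on an amide-type nitrogen. Among the compounds with values here, the only measured step that bears on this is a 13-fold higher number from compound 1 to compound 2 (1.11 log units; beyond the scatter), which went the other way round: the ((4-hydroxyphenyl)carbamoyl)amino group arriving on the amide-type nitrogen brought the large rise. Compound 4 removes that group again and carries 4-chlorophenyl, a close relative of the 4-(trifluoromethyl)phenyl of compound 1, so the large step is expected to reverse. The expected step is a 12-fold lower number from compound 2 to compound 4 (1.07 log units; beyond the scatter). Compound 4 is therefore estimated at 8000 nM, within a range of 3000 nM to 25000 nM.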

Compound 4, half-maximal inhibitory concentration: 19000 nM
Compound 4: the middle estimate sits 2.4-fold (0.38 log units) below what was measured, within the range that was stated.
By their numbers in this assay, from the lowest: compound 3; then compound 1; then compound 4; then compound 2.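

Replacing the ((4-hydroxyphenyl)carbamoyl)amino group on the amide-type nitrogen with 4-chlorophenyl recovers only part of the earlier rise: this assay shows a 5.0-fold lower number from compound 2 to compound 4 (0.70 log units; beyond the scatter) and not a full return to the level of compound 1. The substituent on the aromatic ring therefore also counts at this position, with a 2.6-fold higher number from compound 1 to compound 4 (0.41 log units; beyond the scatter) when chloro stands in place of trifluoromethyl on an aromatic carbon. Nothing available explains why the chloro and trifluoromethyl compounds differ in this way.

The compounds shown leave open how an unsubstituted phenyl ring, a 4-methoxyphenyl ring or a 4-cyanophenyl ring would read on the same nitrogen. Going by these compounds, it also remains open whether adding a second chloro group to the ring of compound 4 would lower the number.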